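Swapping the Ring on a Sulfonamide Nitrogen

This account rests on a few compounds, and the source may have more. Where it says the series, first, only, none or still open, it means among the compounds named here.

Of the compounds shown here, three have been measured in an assay on HEK293-A cells for inhibition of sodium channel protein type 9 subunit alpha/beta-1/beta-2 (Mus musculus), read by patch clamp; on this read-out lower numbers stand for stronger inhibition and higher numbers for weaker inhibition. Compound 3 `Cn1nccc1[C@H]1CCC[C@@H]1Oc1cc(F)c(S(=O)(=O)Nc2nccs2)cc1F` gives 100 nM, the lowest number among them. Compound 1 `Cn1nccc1[C@H]1CCCC[C@@H]1Oc1cc(F)c(S(=O)(=O)Nc2ccncn2)cc1F` gives 400 nM in this assay, and compound 2 `Cn1nccc1CCOc1cc(F)c(S(=O)(=O)Nc2ncns2)cc1F`, which already carries the ring that enters below but on a different linker, gives 35300 nM. Compound 4 `Cn1nccc1[C@H]1CCC[C@@H]1Oc1cc(F)c(S(=O)(=O)Nc2ncns2)cc1F` differs from compound 3 in one place: 1,2,4-thiadiazol-5-yl in place of 1,3-thiazol-2-yl on a sulfonamide nitrogen. Among the compounds with values here, no measured pair isolates this single change, since compound 2 differs from the others in more than this ring. The expectation is a step from compound 3 to compound 4 of a 1.3-fold lower number from compound 3 to compound 4 (0.10 log units; within the scatter), a slight gain that may not reach beyond the usual scatter. Compound 4 is therefore estimated at 80 nM, with a likely range from 25 nM to 300 nM.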

Compound 4, half-maximal inhibitory concentration in the sodium channel protein type 9 subunit alpha/beta-1/beta-2 assay: 240 nM
Beside the measured number, compound 4's estimate is 3.0-fold (0.48 log units) below it; the measured number falls inside the stated range.
By their numbers in the sodium channel protein type 9 subunit alpha/beta-1/beta-2 assay, from the lowest: compound 3; then compounds 4 and 1 (each within the scatter of the next); then compound 2.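

In the sodium channel protein type 9 subunit alpha/beta-1/beta-2 assay, putting 1,2,4-thiadiazol-5-yl in place of 1,3-thiazol-2-yl on the sulfonamide nitrogen gives a 2.4-fold higher number from compound 3 to compound 4 (0.38 log units; beyond the scatter). Within the data shown here, this is the first pair to isolate this ring, and it shows that the swap costs a modest amount of inhibition. In a physicochemical assay for lipophilicity, read by LC-MS, in phosphate buffer, measured as octanol-water partition, with a stated time of 30 min, at pH 7.4 (a higher number here means a more lipophilic compound, a lower number a more polar compound), compound 3 gives 2.1 and compound 4 gives 0.6, so the same swap makes the compound clearly more polar: the measured distribution coefficient of compound 3, 2.1, and of compound 4, 0.6, a number 1.50 log units lower (beyond the scatter)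

Going by these compounds, whether an oxazole or a pyridine on this nitrogen could match compound 3 in the sodium channel protein type 9 subunit alpha/beta-1/beta-2 assay while staying as polar as compound 4 remains open.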